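Carbamate in Place of the Aryloxypropyl Chain

The compounds below may be only part of what the source reports. "The series", "measured", "known", "first", "only" and "open" are said of these compounds alone.

Compound 3 `CC(C)=CCC/C(C)=C/CC1Cc2c(OCCCOc3ccc(Cl)cc3)cc(=O)n(CCCO)c2CC1(C)C` stands lowest of the three measured compounds in a functional assay on PANC-1 cells (Homo sapiens) for inhibition, read by MTT assay, with a stated time of 24 h, tested at 10 uM (on this read-out lower numbers stand for less inhibition and higher numbers for more inhibition at the one concentration tested (going by the name of the read-out)), where compound 3 gives 0%. Compound 1 `CC(C)=CCC/C(C)=C/COc1cc(=O)n(CCCO)c2c1CC(C/C=C(\C)CCC=C(C)C)C(C)(C)C2` gives 3.1% and compound 2 `CC(C)=CCC/C(C)=C/CC1Cc2c(OCCCNC(=O)c3cccs3)cc(=O)n(CCCO)c2CC1(C)C` gives 11.5%. Both changes at the same oxygen stayed small to modest: a number 3.1 percentage points lower from compound 1 to compound 3 (within the scatter) and a number 11.5 percentage points lower from compound 2 to compound 3 (beyond the scatter). Compound 4 `COc1ccc(NC(=O)Oc2cc(=O)n(CCCO)c3c2CC(C/C=C(\C)CCC=C(C)C)C(C)(C)C3)cc1` carries the change ((4-methoxyphenyl)carbamoyl in place of 3-(4-chlorophenoxy)propyl on an oxygen on an aromatic ring), placing the (4-methoxyphenyl)carbamoyl group on the oxygen on the aromatic ring. Among the measured compounds shown here, no measured compound carries a carbamoyl group there, so the expectation rests only on those two steps, and no step beyond the scatter is expected in this assay. Compound 4 is therefore expected to give 5%, between 0% and 20%. The expected step is a number 5 percentage points higher from compound 3 to compound 4 (within the scatter).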

Compound 4, a percentage reported as inhibition, at one concentration (the size of the read-out at that concentration, not a potency): 0%
Compound 4: middle estimate off by 5 percentage points, on the high side; low and high end bracket the measured number.
By their numbers in this assay, from the lowest: compounds 3, 4, 1 and 2 (each within the scatter of the next, the first and the last beyond it).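

In this assay, replacing the chain on the oxygen on the aromatic ring with (4-methoxyphenyl)carbamoyl gives no change at the digits printed from compound 3 to compound 4 (within the scatter) and a number 3.1 percentage points lower from compound 1 to compound 4 (within the scatter), so this carbamoyl group reads no differently from the 3-(4-chlorophenoxy)propyl or 3,7-dimethylocta-2,6-dien-1-yl groups. Only the thiophene amide chain separates from it, with a number 11.5 percentage points lower from compound 2 to compound 4 (beyond the scatter). Nothing available explains these results. On these data alone, whether a chain ending in an amine or a carboxylic acid on this oxygen would raise the inhibition remains open.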